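Aryl swap on the exocyclic chain: compound 3 to compound 4

The compounds below may be only part of what the source reports. "The series", "measured", "known", "first", "only" and "open" are said of these compounds alone.

The shared core is varied only at the double-bonded chain carbon bound to a double-bonded ring carbon. Compound 1 `CCOC(=O)C1=C(Nc2ccccc2)S/C(=C\c2cccc(C(=O)O)c2)C1=O` gives 11700 nM in a functional assay on JAR cells (Homo sapiens) for inhibition, read by MTT assay, with a stated time of 72 h; on this read-out higher numbers stand for weaker inhibition and lower numbers for stronger inhibition. Compound 2 `CCOC(=O)C1=C(Nc2ccccc2)S/C(=C\c2ccccc2O)C1=O` gives 8000 nM in this assay, and compound 3 `CCOC(=O)C1=C(Nc2ccccc2)S/C(=C\c2ccc[nH]2)C1=O` gives 9500 nM. Compound 3 stands second highest of the three numbers; its nearest neighbour is compound 2, with a 1.2-fold higher number from compound 2 to compound 3 (0.07 log units; within the scatter), and its furthest is compound 1, with a 1.2-fold lower number from compound 1 to compound 3 (0.09 log units; within the scatter). The remaining exchange at this position, a 1.5-fold lower number from compound 1 to compound 2 (0.17 log units; within the scatter), also stays within the scatter.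

Compound 4 `CCOC(=O)C1=C(Nc2ccccc2)S/C(=C\c2cc3ncccc3[nH]2)C1=O` is not yet measured. It differs from compound 3 by a group of 9 heavy atoms (7 carbon, 2 nitrogen; one five-membered aromatic ring with 1 hetero atom, one six-membered aromatic ring with 1 hetero atom) in place of a group of 5 heavy atoms (4 carbon, 1 nitrogen; one five-membered aromatic ring with 1 hetero atom), on a double-bonded chain carbon bound to a double-bonded ring carbon. Among the compounds with values here, the steps that bear on this change are the three exchanges at the same position, from compound 1 to compound 2, from compound 1 to compound 3 and from compound 2 to compound 3, none of which moved the number in this assay beyond the scatter. On that basis no step beyond the scatter is expected, and the estimate means a 1.1-fold lower number from compound 3 to compound 4 (0.02 log units; within the scatter). Compound 4 is estimated at 9000 nM, with a range from 3000 nM to 27000 nM.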

Compound 4, half-maximal inhibitory concentration: 9600 nM
Compound 4: the middle estimate sits 1.1-fold (0.03 log units) below what was measured; the measured number falls inside the stated range.
By their numbers in this assay, from the lowest: compounds 2, 3, 4 and 1 (each within the scatter of the next).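

In this assay, the exchange of 1H-pyrrol-2-yl for the group of 9 heavy atoms on the double-bonded chain carbon bound to a double-bonded ring carbon brings in a second aromatic ring and 1 hydrogen-bond acceptor, and the result is a 1.0-fold higher number from compound 3 to compound 4 (0.00 log units; within the scatter) with no move beyond the scatter. Against the two phenyl-bearing groups, the same group gives a 1.2-fold higher number from compound 2 to compound 4 (0.08 log units; within the scatter) and a 1.2-fold lower number from compound 1 to compound 4 (0.09 log units; within the scatter) so that, unlike the earlier single-ring groups, it extends the flat picture at this position to a group with a five-membered and a six-membered aromatic ring, each with 1 hetero atom. No measurement shown here offers a reason why these four numbers stay together.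

Going by these compounds, all four groups at this position are aromatic, so it remains open whether a saturated amine such as morpholine or a longer alkyl chain on the same carbon would give a step beyond the scatter. The ethyl ester and the anilino group are constant throughout, which leaves open whether a carboxylic acid in place of the ester, or a substituent on the anilino ring, would move the number in this assay.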